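The source may hold more compounds than are shown below. What is called first, only, known or untested is meant among the compounds shown, and "the series" means these compounds.

Measured compounds:
Compound 1 `Nc1nc(Br)cn2cc(-c3ccccc3)nc12`, an assay on cells for displacement of a labelled ligand from transmembrane domain-containing protein TMIGD3 (Homo sapiens), read by scintillation counting, with a stated time of 120 min, tested at 1 uM; on this read-out higher numbers stand for more inhibition at the one concentration tested (going by the name of the read-out) and lower numbers for less inhibition: 14%
Compound 2 `COc1ccc(-c2cn3cc(Br)nc(N)c3n2)cc1`: 24%

Compound 1 gives the lower of the two numbers in this assay, but the gap to compound 2, a number 10 percentage points higher from compound 1 to compound 2 (within the scatter), is within the scatter. Compound 3 `Nc1nc(-c2ccc(Cl)cc2)cn2cc(-c3ccccc3)nc12` differs from compound 1 by 4-chlorophenyl in place of bromo on an aromatic carbon. For the measured compounds named here, no measured step bears on this change; the one known step concerns a methoxy on the phenyl and is within the scatter, so nothing constrains the size or direction of a step here. Compound 3 is expected to give 25% (range 5% to 55%). The expected step is a number 11 percentage points higher from compound 1 to compound 3 (beyond the scatter), with wide uncertainty.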

Compound 3, a percentage reported as inhibition, at one concentration (the size of the read-out at that concentration, not a potency): 1%
Compound 3: middle estimate off by 24 percentage points, on the high side, outside the stated range (below it).
By their numbers in this assay, from the lowest: compound 3; then compounds 1 and 2 (each within the scatter of the next).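

In this assay, for the compounds shown here, the position next to the ring nitrogen is the first place where a change moves the number beyond the scatter: a number 13 percentage points lower from compound 1 to compound 3 (beyond the scatter). The methoxy step on the phenyl did not separate from the scatter, so this position is the only one so far shown to respond to its substituent, with 4-chlorophenyl giving less inhibition than bromo. Nothing available explains this step.

Going by these compounds, whether the loss follows the added phenyl ring or its chlorine stays open. On these data alone, how a small amine, such as dimethylamino, or a carboxylic acid would read at this position also stays open.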